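The source may hold more compounds than are shown below. What is called first, only, known or untested is meant among the compounds shown, and "the series" means these compounds.

Compound 1 `O=C(O)CC1COc2cc(OCc3cn(-c4ccccc4Cl)nn3)ccc21` has no single number in a physicochemical assay for lipophilicity, read by HPLC, using the shake flask method, in phosphate buffer, measured as octanol-water partition, with a stated time of 24 h, at pH 7.4, tested at 100 uM; a lower number here means a more polar compound, a higher number a more lipophilic compound: for compound 1 the result is recorded as "not determined" (no result reported). A close relative, compound 2 `O=C(O)CC1COc2cc(OCc3cn(-c4cccc(Cl)c4)nn3)ccc21`, does carry a value in this assay, where compound 2 gives 1.09. Compound 3 `Cc1ccc(Cl)cc1-n1cc(COc2ccc3c(c2)OCC3CC(=O)O)nn1` has not yet been measured. The change from compound 1 to compound 3 is 5-chloro-2-methylphenyl in place of 2-chlorophenyl on an aromatic nitrogen. Going by the values given here, no measured pair shows this step, so its size is unknown; a modest rise in this assay is expected rather than none. For compound 3 the value in this assay is estimated at 1.45, within a range from 0.95 to 1.95.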

Compound 3, distribution coefficient: 2.08
For compound 3 the middle estimate is 0.63 log units below the measured one; measured number above the stated range.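

In this assay, putting methyl in place of hydrogen on an aromatic carbon of the phenyl ring gives a number 0.99 log units higher from compound 2 to compound 3 (beyond the scatter). Going by these compounds alone, this is the first readable step at this part of the molecule, and it shows that adding one small group can shift the read-out clearly. The step from compound 1 to compound 3 cannot be read, and nothing shown here accounts for the size of the step from compound 2.

Going by these compounds, whether an ethyl or a methoxy group in place of that methyl would give a similar shift remains open. So does the effect of an amine at the same carbon.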